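Series of pyridyl-hexenoic acids as thromboxane synthase inhibitors

A few compounds are considered here, and "the series" means these few. Any claim that something is new, unique, unknown or untested is made for them only; others in the source may bear on it.

Three measured compounds set the frame. Compound 1 `O=C(O)CCCC/C=C\c1cccnc1` gives 250 nM in an assay (Equus caballus) for inhibition of Thromboxane-A synthase (Homo sapiens), using microsomes; a higher number here means a weaker inhibitor, a lower number a stronger inhibitor. Compound 3 `O=C(O)C(CCC/C=C(\c1cccnc1)c1cccs1)c1ccccc1` gives 50 nM in this assay. Compound 2 `CCOC(=O)CCCC/C=C(\c1ccccc1)c1cccnc1` gives 600 nM in this assay and therefore stands at the highest number of the three, weaker than compound 1 and much weaker than compound 3, both steps beyond the scatter.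

Compound 4 `C=C(C)C(CCC/C=C(\c1ccccc1)c1cccnc1)C(=O)O` is the next one to be measured. Its difference from compound 2 is 1-carboxy-2-methylprop-2-en-1-yl in place of (ethoxycarbonyl)methyl on a saturated chain carbon, three bonds along the chain from a double-bonded chain carbon. The change brings one hydrogen-bond donor in and takes one acceptor out, and it adds one double bond outside the aromatic rings. Going by the values given here, no measured pair shows this exact change, so the step is judged from the three values. Compound 3, which also carries a carboxy group on a saturated chain carbon, gives 50 nM, so the direction expected is toward a lower number. The step from compound 2 to compound 4 is expected as a 6.0-fold lower number from compound 2 to compound 4 (0.78 log units; beyond the scatter), clearly beyond the scatter. Compound 4 is expected at 100 nM, within 30 nM to 400 nM.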

Compound 4, half-maximal inhibitory concentration: 28 nM
The estimate for compound 4 lay 3.6-fold (0.55 log units) above the measured number, and the stated range ends above it.
By their numbers in this assay, from the lowest: compounds 4 and 3 (each within the scatter of the next); then compound 1; then compound 2.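

In this assay, going by these compounds alone, 1-carboxy-2-methylprop-2-en-1-yl in place of (ethoxycarbonyl)methyl on a saturated chain carbon, three bonds along the chain from a double-bonded chain carbon, gives a 21-fold lower number from compound 2 to compound 4 (1.33 log units; beyond the scatter) and provides the first single-place comparison. This position is therefore not limited to the ester-bearing group of compound 2, and the change produces a large gain in inhibition. The data on hand offer no explanation for the size of this step.

The change combines a free carboxy group with a branch, so a plain carboxylic acid on the chain of compound 2 and the ethyl ester of compound 4 would be needed to separate the two contributions. Also open, going by these compounds, is whether a simple methyl branch, or an amide in place of the carboxylic acid, would retain the inhibition seen for compound 4 at 28 nM.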